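The source may hold more compounds than are shown below. What is called first, only, known or untested is meant among the compounds shown, and "the series" means these compounds.

Compound 1 (`COc1cc(OC)c(-c2coc3cc(OCc4ccccc4C)ccc3c2=O)cc1OC`), compound 2 (`COc1cc(OC)c(-c2coc3cc(OCc4ccc(C#N)cc4)ccc3c2=O)cc1OC`) and compound 3 (`COc1cc(OC)c(-c2coc3cc(OCc4ccccc4Br)ccc3c2=O)cc1OC`) share one core and differ only in the aromatic group on a saturated chain carbon bound to an oxygen on an aromatic ring. In a functional assay on HepG2 cells (Homo sapiens) for antiproliferative activity, read by MTT assay, with a stated time of 24 h (on this read-out lower numbers stand for stronger inhibition and higher numbers for weaker inhibition), compound 1 gives 1860 nM, compound 2 gives 4230 nM and compound 3 gives 2180 nM. Compound 3 lies within the scatter of both others, as a 1.2-fold higher number from compound 1 to compound 3 (0.07 log units; within the scatter) and a 1.9-fold lower number from compound 2 to compound 3 (0.29 log units; within the scatter) show, and only a 2.3-fold higher number from compound 1 to compound 2 (0.36 log units; beyond the scatter) goes beyond it.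

Compound 4 (`COc1cc(OC)c(-c2coc3cc(OCc4ccc(C(F)(F)F)cc4)ccc3c2=O)cc1OC`), not yet measured, carries 4-(trifluoromethyl)phenyl in place of the 2-bromophenyl of compound 3: 4-(trifluoromethyl)phenyl in place of 2-bromophenyl on a saturated chain carbon bound to an oxygen on an aromatic ring. Among the measured compounds shown here, no measured step makes this exact exchange. The closest guide is compound 2, with its 4-cyanophenyl group, at 4230 nM, and the steps among these compounds are all modest. In this assay the estimated step is a 1.4-fold higher number from compound 3 to compound 4 (0.14 log units; within the scatter), so a slightly higher number is expected, but nothing clearly beyond the scatter. Compound 4 is estimated at 3000 nM, with an expected range of 1500 nM to 6000 nM.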

Compound 4, half-maximal inhibitory concentration: 890 nM
Compound 4: the middle estimate sits 3.4-fold (0.53 log units) above what was measured; measured number below the stated range.
By their numbers in this assay, from the lowest: compound 4; then compounds 1, 3 and 2 (each within the scatter of the next, the first and the last beyond it).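

In this assay, compound 4 is the only compound shown whose steps to all the others lie beyond the scatter, with a 2.4-fold lower number from compound 3 to compound 4 (0.39 log units; beyond the scatter) and a 2.1-fold lower number from compound 1 to compound 4 (0.32 log units; beyond the scatter) from the two nearest compounds, so changing the aromatic group at this place can lower the number as well as raise it. The largest change comes from one exchange on a single aromatic carbon, a 4.8-fold lower number from compound 2 to compound 4 (0.68 log units; beyond the scatter) for trifluoromethyl in place of cyano, so the identity of this one group matters greatly. Nothing measured here explains this change.

As far as these compounds go, it remains open whether trifluoromethyl would give a similar number in the place held by bromo in compound 3. From the compounds shown here alone, the effect of an amine or a carboxylic acid on this aromatic ring, or of a longer chain leading to it, also remains open.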